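The source may hold more compounds than are shown below. What is called first, only, known or untested is meant among the compounds shown, and "the series" means these compounds.

The series rests on a shared core, that of compound 1 `CC(C)(C)c1ccc(S(=O)(=O)Nc2ccccc2)cc1`, which in a functional assay on A549 cells (Homo sapiens) for inhibition (a lower number here means a stronger inhibitor of growth, a higher number a weaker inhibitor of growth), gives a value for compound 1 of 16000 nM. Compound 2 `CC(C)(C)c1ccc(S(=O)(=O)Nc2ccccc2O)cc1` carries the change hydroxy in place of hydrogen on an aromatic carbon on that core, and in this assay compound 2 gives 13000 nM, a step of a 1.2-fold lower number from compound 1 to compound 2 (0.09 log units; within the scatter). Compound 3 `Cc1ccc(NS(=O)(=O)c2ccc(C(C)(C)C)cc2)cc1` differs from compound 1 by methyl in place of hydrogen on an aromatic carbon, and in this assay compound 3 gives 11000 nM, a step of a 1.5-fold lower number from compound 1 to compound 3 (0.16 log units; within the scatter). Between compound 2 and compound 3 the step is a 1.2-fold lower number from compound 2 to compound 3 (0.07 log units; within the scatter). Compound 3 holds the lowest of the three numbers, but all three values sit within the scatter of one another, so no order among them can be claimed.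

Compound 4 `Cc1ccc(NS(=O)(=O)c2ccc(C(C)(C)C)cc2)cc1O` is not yet measured. Within the data shown here, it stands to compound 3 as compound 2 stands to compound 1: the change is hydroxy in place of hydrogen on an aromatic carbon, the same kind of change as the one from compound 1 to compound 2, the cores themselves differing by methyl in place of hydrogen on an aromatic carbon. The surroundings of the place are not identical, however: in compound 2 the hydroxy sits ortho to a large group, whereas in compound 4 it sits ortho to a methyl group and meta to a large group.

Because the earlier step of a 1.2-fold lower number from compound 1 to compound 2 (0.09 log units; within the scatter) stayed within the scatter, a step of about a 1.1-fold lower number from compound 3 to compound 4 (0.04 log units; within the scatter) is expected in this assay for compound 4. In this assay compound 4 is therefore estimated at 10000 nM, with a range expected from 4500 nM to 22000 nM.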

Compound 4, concentration for 50% growth inhibition: 6000 nM
For compound 4 the middle estimate is 1.7-fold (0.22 log units) above the measured one; measured number inside the range.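

In this assay the hydroxy group on the core of compound 3 gives a 1.8-fold lower number from compound 3 to compound 4 (0.26 log units; within the scatter), so this step, like the earlier one on the core of compound 1, stays within the scatter. Set side by side, the two steps do not differ by more than repeated measurement would allow: the same change on two cores in this assay, a 1.2-fold lower number (0.09 log units; within the scatter) from compound 1 to compound 2 and a 1.8-fold lower number (0.26 log units; within the scatter) from compound 3 to compound 4, 1.5-fold (0.17 log units) apart, within the scatter of two such steps. This shows that, across these two pairs, the change carries from one core to the other without a detectable difference, but since neither step stands clear of the scatter, it shows neither that the hydroxy group improves growth inhibition on either core nor that the two cores respond in the same way to a change with a larger effect.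

The compounds shown leave open whether a methoxy group, an amine or a carboxylic acid in place of the hydroxy group would give a step beyond the scatter on either core. They also leave open whether the hydroxy step would stay this small if the tert-butyl group on the other aromatic ring gave way to a trifluoromethyl group or a longer chain.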